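The source may hold more compounds than are shown below. What is called first, only, known or untested is meant among the compounds shown, and "the series" means these compounds.

In an ADME assay on THP-1 cells (Homo sapiens) for cytotoxicity, read by resazurin assay, with a stated time of 72 h (on this read-out lower numbers stand for higher toxicity in this test and higher numbers for lower toxicity in this test), three compounds have been measured so far:
compound 1, `CSc1ccc(C(=O)/C=C/c2ccc([N+](=O)[O-])o2)cc1`, gives 13100 nM;
compound 2, `CCCCc1ccc(C(=O)/C=C/c2ccc([N+](=O)[O-])o2)cc1`, gives 48700 nM;
compound 3, `CCCCc1ccc(C(=O)/C=C/c2ccc([N+](=O)[O-])s2)cc1`, gives 17100 nM.

Among the measured compounds shown here, the one counted step within this set is a 3.7-fold lower number from compound 2 to compound 1 (0.57 log units; beyond the scatter), the change being (methylsulfanyl in place of butyl on an aromatic carbon). Compound 3 and compound 2 share the butyl group but differ elsewhere; how their two cores differ is not broken down here, and their values simply show a lower number for compound 3 than for compound 2 in this assay. The values of compound 3 and compound 1 lie within the scatter of each other, so nothing is said about their order.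

Compound 4, `CSc1ccc(C(=O)/C=C/c2ccc([N+](=O)[O-])s2)cc1`, has not yet been measured. It differs from compound 3 by methylsulfanyl in place of butyl on an aromatic carbon, the same change that carries compound 2 to compound 1. For the measured compounds named here, compound 4 is therefore expected to show a step of about a 2.9-fold lower number from compound 3 to compound 4 (0.45 log units; beyond the scatter), a size that rests on the single earlier step of a 3.7-fold lower number from compound 2 to compound 1 (0.57 log units; beyond the scatter). On this basis compound 4 is estimated at 6000 nM, with a range from 2500 nM to 15000 nM.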

Compound 4, half-maximal cytotoxic concentration: 8560 nM
Compound 4: middle estimate off by 1.4-fold (0.15 log units), on the low side; low and high end bracket the measured number.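

In this assay, methylsulfanyl in place of butyl on an aromatic carbon gives a 2.0-fold lower number from compound 3 to compound 4 (0.30 log units; within the scatter), a step that by itself cannot be told apart from the scatter of repeated measurements. Set beside the step on the other core, it does not differ from it by more than such scatter allows: the same change on two cores in this assay, a 3.7-fold lower number (0.57 log units; beyond the scatter) from compound 2 to compound 1 and a 2.0-fold lower number (0.30 log units; within the scatter) from compound 3 to compound 4, 1.9-fold (0.27 log units) apart, within the scatter of two such steps. Among the compounds shown here, the two cores therefore give no sign that the size of this step depends on the core, but with only one pair on each core, and only one of the two steps beyond the scatter, this does not show that the change carries over with the same size, nor does it explain the result.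

The compounds shown leave open what other groups at that aromatic carbon would give, such as an amine, a carboxylic acid or a chain longer than butyl. They also leave open whether the same change would give a step of like size on any core beyond these two.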